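Compound 3: one methyl fewer than compound 2

A few compounds are considered here, and "the series" means these few. Any claim that something is new, unique, unknown or untested is made for them only; others in the source may bear on it.

In an ADME assay on microsomes from liver (Homo sapiens) for metabolic stability, read by LC-MS, with a stated time of 10 min, tested at 0.5 uM (a lower number here means that less of the compound is left, a higher number that more of the compound is left), compound 1 (`c1ccc2c(c1)CN[C@@H](CN(CCCN1CCNCC1)[C@H]1CCCc3cccnc31)C2`) gives 100% and compound 2 (`CN1CCN(CCCN(C[C@H]2Cc3ccccc3CN2C)[C@H]2CCCc3cccnc32)CC1`) gives 60% as the lower of the two numbers, a gap beyond the usual scatter. Compound 3 (`CN1CCN(CCCN(C[C@H]2Cc3ccccc3CN2)[C@H]2CCCc3cccnc32)CC1`) differs from compound 2 by hydrogen in place of methyl on an amine nitrogen in a ring with hydrogen in place of methyl on an amine nitrogen in a ring. Among the measured compounds shown here, no measured pair shows this change alone, so the expectation rests only on compound 1 at 100% as the single higher reference. A rise beyond the scatter is expected, estimated as a number 18 percentage points higher from compound 2 to compound 3 (beyond the scatter) in size. Compound 3 is estimated at 78% with an expected range of 60% to 100% for now.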

Compound 3, percent of the compound remaining: 72%
For compound 3 the middle estimate is 6 percentage points above the measured one, within the range that was stated.
By their numbers in this assay, from the lowest: compound 2; then compound 3; then compound 1.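

Hydrogen in place of methyl on the amine nitrogen in the ring gives, in this assay, a number 12 percentage points higher from compound 2 to compound 3 (beyond the scatter) and so puts this change alone on record for the first time. Methyl in place of hydrogen on a different amine nitrogen in a ring gives a number 28 percentage points lower from compound 1 to compound 3 (beyond the scatter) and shows that, in these two pairs, a methyl at either nitrogen goes with less compound left. Nothing measured here accounts for either step.

Open, as far as these compounds go, is how an ethyl group or an acetyl group on the amine nitrogen in the ring would read.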